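The compounds below may be only part of what the source reports. "The series", "measured", "known", "first", "only" and "open" are said of these compounds alone.

Values so far in a functional assay on HT-29 cells (Homo sapiens) for cytotoxicity; a higher number here means that more compound is needed for the effect, a lower number that less compound is needed:
compound 1 `COc1ccc(/C=C/c2cc(OC)c(OC(C)=O)c(OC)c2)cc1`: 11.7 uM
compound 2 `COc1ccc(/C=C/c2cc(OC)c(OCc3ccccc3)c(OC)c2)cc1`: 17.8 uM

Compound 2 stands at 17.8 uM. The two values lie within the scatter of each other, so no order can be drawn between them. Going by the values given here, the only measured step, a 1.5-fold higher number from compound 1 to compound 2 (0.18 log units; within the scatter), puts benzyl in place of acetyl on an oxygen on an aromatic ring.

Compound 3 `COc1ccc(/C=C\c2cc(OC)c(OCc3ccccc3)c(OC)c2)cc1` has the same atoms and bonds as compound 2: the two compounds have the same atoms and bonds and differ only in configuration as drawn: 1 of 1 stereo elements differ; a double bond is drawn E in compound 2 and Z in compound 3. The measured step concerns a different kind of change and is the only one available. Among the compounds with values here, no measured pair differs in the configuration of the double bond, so the data fix neither the size nor the direction of this step. A moderate move toward a lower number is taken as a tentative working expectation, and the range is kept wide. The expected change is a 2.2-fold lower number from compound 2 to compound 3 (0.35 log units; beyond the scatter). For compound 3 the estimated value is 8 uM, with an expected range of 1.5 uM to 30 uM.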

Compound 3, concentration for half-maximal effect: 9.5 uM
Beside the measured number, compound 3's estimate is 1.2-fold (0.07 log units) below it; the range from low to high includes it.
By their numbers in this assay, from the lowest: compounds 3, 1 and 2 (each within the scatter of the next).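

Working notes on the double bond: this pair gives the series its first reading of configuration at the double bond, with the benzyl group on the oxygen and the rest of the structure held fixed, so any difference between the two values can be set against a single variable: the fact that compounds 2 and 3 differ only in the configuration as drawn

In this assay the result is a 1.9-fold lower number from compound 2 to compound 3 (0.27 log units; within the scatter), so at this double bond, with benzyl on the oxygen, the change from E to Z cannot be told apart from repeat-measurement noise, and neither drawn form can be ranked over the other. The configuration change thus joins a 1.5-fold higher number from compound 1 to compound 2 (0.18 log units; within the scatter) as a second single change in the series whose size stays inside the scatter.

The compounds shown leave open whether the same reading of the double bond holds with acetyl rather than benzyl on that oxygen. They also leave open whether a chain carrying an amine or a carboxylic acid on that oxygen would give a step beyond the scatter in this assay, in either drawn form of the double bond.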